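Chalcone analogues against K562 cells: from compound 2 to compound 4

The source may hold more compounds than are shown below. What is called first, only, known or untested is meant among the compounds shown, and "the series" means these compounds.

Three compounds of one family share a core and differ in the aromatic group at the far end of the double-bonded chain. Compound 1 `COc1cc(OC)c(OC)cc1/C=C/C(=O)c1ccc(OC)c2c1OC(C)(C)C=C2` is inactive in a functional assay on K562 cells (Homo sapiens) for antiproliferative activity, read by MTT assay, with a stated time of 24 h; on this read-out lower numbers stand for stronger inhibition and higher numbers for weaker inhibition; compound 1 reaches only the limit > 10000 nM, which is not a number. Compound 2 `COc1ccc(C(=O)/C=C/c2ccc(Br)cc2)c2c1C=CC(C)(C)O2` likewise gives only the limit > 10000 nM in this assay. Compound 3 `COc1ccc(C(=O)/C=C/c2ccc3ccccc3c2)c2c1C=CC(C)(C)O2` gives 3670 nM in this assay. Compound 2 therefore stands at the weak end of what is shown, alongside compound 1, at the limit of > 10000 nM in this assay, at which 2 of the 3 values shown sit, while compound 3 is the one compound with a measurable number.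

Compound 4 `COc1ccc(C(=O)/C=C/c2cc(Cl)ccc2O)c2c1C=CC(C)(C)O2` has not yet been measured. It differs from compound 2 in one place: 5-chloro-2-hydroxyphenyl in place of 4-bromophenyl on a double-bonded chain carbon bound to a double-bonded chain carbon. Among the compounds with values here, no measured pair differs in only one place, so the size of this step cannot be read from a comparison of measured compounds. Since compound 2 sits at a limit, the step from compound 2 to compound 4 in this assay can only be estimated in direction: a move toward a lower number is expected, of uncertain size, and it may not exceed the usual scatter. Compound 4 is expected to give about 8000 nM in this assay, with a range from 2500 nM to 30000 nM, so that the estimated step of an at least 1.2-fold lower number from compound 2 to compound 4 (0.09 log units; that floor lies within the scatter) remains tentative.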

Compound 4, half-maximal inhibitory concentration: 5510 nM
Compound 4: the middle estimate sits 1.5-fold (0.16 log units) above what was measured, and the stated range covers the measured number.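

Swapping 4-bromophenyl for 5-chloro-2-hydroxyphenyl on a double-bonded chain carbon bound to a double-bonded chain carbon gives the first step that can be read in this family: in this assay the change gives an at least 1.8-fold lower number from compound 2 to compound 4 (0.25 log units; that floor lies within the scatter). Going by these compounds, this step is only a floor and not a measured distance, since compound 2 carries a limit rather than a number: the limit of > 10000 nM in this assay, at which 2 of the 4 values shown sit. What the change does show is that the new aromatic group, with its hydroxy group and its chlorine, turns a limit into a measurable number at this place, although the true size of the gain remains unknown and the floor does not clear the usual scatter.

The swap alters the halogen, the place of that halogen on the ring and the presence of a hydroxy group all at once, and the compounds shown cannot separate these contributions. On these data alone, it also remains open how this place would respond to a phenyl ring carrying only the hydroxy group, only the chlorine, or an amine or a carboxylic acid instead.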